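This account rests on a few compounds, and the source may have more. Where it says the series, first, only, none or still open, it means among the compounds named here.

Compound 1 `Nc1nc(NCc2ccccc2)c2ncn(/C=C3/CC3(CO)CO)c2n1` gives > 300000 nM in an ADME assay on HFF cells (Homo sapiens) for cytotoxicity, with a stated time of 8 days; a lower number here means that less compound is tolerated, a higher number that more compound is tolerated; this is a limit of the assay, not a number.
Compound 2 `Nc1nc2c(ncn2/C=C2/CC2(CO)CO)c(=O)[nH]1` gives > 300000 nM in this assay, again a limit.

Compound 1 stands at the limit of > 300000 nM in this assay, at which 2 of the 2 values shown sit, so no cytotoxic concentration was reached for either measured compound. Compound 3 `CCCOc1nc(N)nc2c1ncn2/C=C1/CC1(CO)CO` is not yet measured. It differs from compound 1 by propoxy in place of benzylamino on an aromatic carbon. Among the compounds with values here, no measured step exists here, so the expectation rests on the two limits alone. The change is expected to give a number no higher from compound 1 to compound 3 (the limit leaves the size open), nothing beyond the scatter. Compound 3 is therefore estimated at 300000 nM, with a range from 100000 nM to 1000000 nM, most likely reported once more as a limit only.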

Compound 3, half-maximal cytotoxic concentration: > 300000 nM
Compound 3: only a limit was reported; the forecaster's own chance of this, stated with the estimate: 80%; the middle value sits exactly at the limit.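

Compound 1 and compound 3 both give only a limit, so no step can be read between them: the limit of > 300000 nM in this assay, at which 3 of the 3 values shown sit. Still open is the concentration at which any of these compounds would become cytotoxic in this assay.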